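The source may hold more compounds than are shown below. What is called first, only, known or untested is meant among the compounds shown, and "the series" means these compounds.

In a physicochemical assay for solubility, measured as kinetic solubility, at pH 6.5 (a lower number here means a less soluble compound, a higher number a more soluble compound), compound 1 (`CCCC(Nc1ccc(-n2cnc(C(F)(F)F)c2)cc1)c1ccc(C(=O)NCCC(=O)O)cc1`) gives 350000 nM and compound 2 (`CCCC(Oc1ccc(-n2cc(Cl)cn2)cc1)c1ccc(C(=O)NCCC(=O)O)cc1`) gives 70000 nM as the lower of the two numbers, clearly apart from compound 1. Compound 3 (`CCCC(Oc1ccc(-n2cc(C(F)(F)F)cn2)cc1)c1ccc(C(=O)NCCC(=O)O)cc1`) keeps the core of compound 2 but carries trifluoromethyl in place of chloro on an aromatic carbon. Among the compounds with values here, no measured pair shows this swap, so the expectation starts from compound 2 at 70000 nM and allows only a small drop. The expected change is a 1.4-fold lower number from compound 2 to compound 3 (0.15 log units; within the scatter) in this assay and stays within the scatter, slightly downward if anything. The estimated value for compound 3 is 50000 nM (range 15000 nM to 150000 nM).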

Compound 3, solubility: 400000 nM
The estimate for compound 3 lay 8.0-fold (0.90 log units) below the measured number; the measured number lies above the stated range.
By their numbers in this assay, from the lowest: compound 2; then compounds 1 and 3 (each within the scatter of the next).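

In this assay, trifluoromethyl in place of chloro on an aromatic carbon of the five-membered aromatic ring gives a 5.7-fold higher number from compound 2 to compound 3 (0.76 log units; beyond the scatter) and so shows that this one position can move the number upward, beyond the scatter. The earlier compounds shown here offered no pair that differs in one place. No measurement shown here accounts for the step.

A single pair cannot show whether other groups at this position, such as a nitrile or a methyl, would follow the same direction. As far as these compounds go, whether the swap would act alike on another core also remains open.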